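Sulfonyl aryl exchange on a benzoxazole sulfonamide

This account rests on a few compounds, and the source may have more. Where it says the series, first, only, none or still open, it means among the compounds named here.

Measured compounds:
- compound 1, `O=S(=O)(Nc1ccc2oc(-c3ccc(NS(=O)(=O)c4cccc5nonc45)cc3)nc2c1)c1ccc(Cl)s1`: 13000 nM
- compound 2, `O=S(=O)(Nc1ccc(-c2nc3ccccc3o2)cc1)c1cccc(F)c1`: 71000 nM
- compound 3, `COc1ccc(Cl)cc1S(=O)(=O)Nc1ccc2oc(-c3ccccc3)nc2c1`: > 100000 nM

In an assay on cells for inhibition of HSP60/HSP10 (Homo sapiens), with a stated time of 60 min (on this read-out lower numbers stand for stronger inhibition and higher numbers for weaker inhibition), compound 2 gives 71000 nM, the higher of the two numbers recorded, and the gap to compound 1 lies beyond the usual scatter. For compound 3 the assay reports only a limit, > 100000 nM, as noted in the limit of > 100000 nM in this assay, at which 1 of the 3 values shown sits.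

Compound 4, `COc1ccccc1S(=O)(=O)Nc1ccc(-c2nc3ccccc3o2)cc1`, is not yet measured. It differs from compound 2 in one place: 2-methoxyphenyl in place of 3-fluorophenyl on a sulfonyl sulfur. Compound 3, which also carries a methoxyphenyl on its sulfonyl sulfur, reached only the limit, so a shift toward weaker inhibition is more likely than toward stronger, though compound 3 also differs in its core and substitution pattern.

The step from compound 2 to compound 4 is expected to be modest, a 1.3-fold higher number from compound 2 to compound 4 (0.10 log units; within the scatter), in the direction of a higher number or none beyond the scatter. Compound 4 is therefore estimated at 90000 nM in this assay. For compound 4 the expected range runs from 30000 nM to 250000 nM.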

Compound 4, half-maximal inhibitory concentration: > 100000 nM
Compound 4: only a limit was reported; the forecaster's own chance of this, stated with the estimate: 40%; middle value at least 1.1-fold (0.04 log units) away from the limit.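

In this assay, 2-methoxyphenyl in place of 3-fluorophenyl on a sulfonyl sulfur gives an at least 1.4-fold higher number from compound 2 to compound 4 (0.14 log units; that floor lies within the scatter). This is the first pair among the compounds shown that differs only in the group at this place, and the exchange brings no stronger inhibition. The value of compound 4 is a limit, and the floor of the step lies within the scatter, so the full size of the change cannot be read: the limit of > 100000 nM in this assay, at which 2 of the 4 values shown sit.

The compounds shown leave open whether the methoxy group itself or its ring placement matters, which 2-fluorophenyl or 3-methoxyphenyl on the sulfonyl sulfur could separate. They also leave open whether an aminophenyl or a carboxyphenyl at this place would give a lower number than compound 2 in this assay.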